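Sulfonyl for Carbonyl on the Ring Nitrogen

The compounds below may be only part of what the source reports. "The series", "measured", "known", "first", "only" and "open" are said of these compounds alone.

Measured in a functional assay on NCI-H1975 cells (Homo sapiens) for inhibition, read by sulforhodamine B assay, tested at 10 uM; a higher number here means more inhibition at the concentration tested (going by the name of the read-out), a lower number less inhibition:
compound 1, `CC(=O)N1N=C(c2ccc(N3CCN(C)CC3)cc2)CC1c1ccc(N(C)C)cc1`: compound 1 gives -1.9%
compound 2, `Cc1ccc(S(=O)(=O)N2N=C(c3ccc(N4CCN(C)CC4)cc3)CC2c2ccc(N(C)C)cc2)cc1`: compound 2 gives 38.1%
compound 3, `CN(C)c1ccc(C2CC(c3ccc(-n4cncn4)cc3)=NN2C(=O)c2cc(Cl)cc(Cl)c2)cc1`: compound 3 gives 8.4%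

Compound 3 holds the second highest of the three numbers in this assay; its step to compound 1 lies beyond the scatter, and compound 2 stands well above it. Compound 4 `CN(C)c1ccc(C2CC(c3ccc(-n4cncn4)cc3)=NN2S(=O)(=O)c2ccc(C#N)cc2)cc1` carries (4-cyanophenyl)sulfonyl in place of (3,5-dichlorophenyl)carbonyl on an amine nitrogen in a ring. Within the data shown here, one measured step bears on this change: a number 40 percentage points higher from compound 1 to compound 2 (beyond the scatter), where a sulfonyl likewise replaced a carbonyl group on an amine nitrogen in a ring. The swap in compound 4 is therefore expected to raise inhibition by a comparable margin, though the aromatic groups attached differ. For compound 4 the estimate is 35%, between 15% and 55%, an expected step of a number 26.6 percentage points higher from compound 3 to compound 4 (beyond the scatter).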

Compound 4, a percentage reported as inhibition, at one concentration (the size of the read-out at that concentration, not a potency): 22.6%
Estimate against measurement, compound 4: 12.4 percentage points above; the measured number falls inside the stated range.
By their numbers in this assay, from the lowest: compound 1; then compound 3; then compound 4; then compound 2.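

In this assay a sulfonyl on the amine nitrogen in a ring again goes with more inhibition, this time alongside the 4-(1H-1,2,4-triazol-1-yl)phenyl group: a number 14.2 percentage points higher from compound 3 to compound 4 (beyond the scatter). The earlier gain of (4-methylphenyl)sulfonyl over acetyl is thus not confined to one pair, although here the aromatic group changes together with the link to the nitrogen. Nothing measured here accounts for this step.

From the compounds shown here alone, whether the sulfonyl or the 4-cyanophenyl part carries the step remains open. So does how (3,5-dichlorophenyl)sulfonyl or a plain methylsulfonyl group would read on this nitrogen.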